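Vinyl in Place of Methoxy on a Low-Extraction Core

The source may hold more compounds than are shown below. What is called first, only, known or untested is meant among the compounds shown, and "the series" means these compounds.

Compound 1 `CCC(CC)n1c(=O)[nH]c2ncc(C)nc21`: < 0.2
Compound 2 `CCC(CC)n1c(=O)[nH]c2ncc(Cl)nc21`: < 0.2
Compound 3 `CCC(CC)n1c(=O)[nH]c2ncc(OC)nc21`: < 0.2

In an ADME assay on microsomes from liver (Homo sapiens), read by LC-MS, with a stated time of 90 min (a lower number here means that the liver removes a smaller share, a higher number that the liver removes a larger share of the compound in one pass), compound 1 sits at a limit of the assay, < 0.2. Compound 2 likewise reaches only a limit, < 0.2. Compound 3 too gives only a limit, < 0.2, so its standing among the three is not readable as a number. The steps a step that the two limits leave unreadable from compound 1 to compound 2, a step that the two limits leave unreadable from compound 1 to compound 3 and a step that the two limits leave unreadable from compound 2 to compound 3 are all unreadable because of the limit of < 0.2 in this assay, at which 3 of the 3 values shown sit.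

Compound 4 `C=Cc1cnc2[nH]c(=O)n(C(CC)CC)c2n1` differs from compound 3 by vinyl in place of methoxy on an aromatic carbon. Among the compounds with values here, no measured step bears on this change, since every pair shown sits at the same limit. Compound 4 is therefore expected to give 0.15, with a range from 0.05 to 0.35, a step that the limit leaves unreadable from compound 3 to compound 4 that is estimated to stay within the scatter.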

Compound 4, hepatic extraction ratio: 0.5
Beside the measured number, compound 4's estimate is 0.35 below it; the measured number lies above the stated range.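

In this assay this position proves able to move the reading: vinyl in place of methoxy gives a number at least 0.30 higher from compound 3 to compound 4 (beyond the scatter) and leaves the limit behind. Vinyl in place of chloro gives a number at least 0.30 higher from compound 2 to compound 4 (beyond the scatter) as well, and vinyl in place of methyl gives a number at least 0.30 higher from compound 1 to compound 4 (beyond the scatter) as well. The steps among compound 1, compound 2 and compound 3 still cannot be read: the limit of < 0.2 in this assay, at which 3 of the 4 values shown sit.

The compounds shown leave open whether the double bond of vinyl is what matters. As far as these compounds go, whether ethyl or an amine here would stay at the limit or read like compound 4 also remains open.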